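The source may report more compounds than this note shows. Statements on the series, on what has been measured and on what is new or still open speak of the compounds shown alone.

Compound 1 `CCOc1ccc(-c2nn3cc(-c4cccc(N)c4)nc3s2)cc1` was tested in a functional assay on FM3A cells (Mus musculus) for inhibition, read by cell counting, with a stated time of 2 days; on this read-out lower numbers stand for stronger inhibition and higher numbers for weaker inhibition. In this assay compound 1 gives >= 250000 nM, which is a limit of the assay rather than a number, so compound 1 sits at the limit of >= 250000 nM in this assay, at which 1 of the 2 values shown sits. Compound 2 `C=C(Br)C(=O)Nc1cccc(-c2cn3nc(-c4ccc(OCC)cc4)sc3n2)c1` carries a (1-bromoethenyl)carbonyl in place of hydrogen on a nitrogen on an aromatic ring, and in this assay compound 2 gives 1100 nM. That step, an at least 220-fold lower number from compound 1 to compound 2 (2.35 log units; beyond the scatter), is the only measured one. Compound 3 `COc1ccc(-c2nn3cc(-c4cccc(N)c4)nc3s2)cc1` differs from compound 1 by hydrogen in place of methyl on a saturated chain carbon bound to an oxygen on an aromatic ring, so ethoxy becomes methoxy. Within the data shown here, no measured step touches this part of the core, and the step from compound 1 to compound 2 concerns another position, so it gives no guide. The expected step is therefore a number no higher from compound 1 to compound 3 (the limit leaves the size open), none beyond the scatter. Compound 3 is estimated at 250000 nM in this assay, between 100000 nM and 400000 nM, most likely again reported only as a limit.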

Compound 3, half-maximal inhibitory concentration: 74000 nM
Compound 3: middle estimate off by 3.4-fold (0.53 log units), on the high side; measured number below the stated range.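

In this assay, the change from ethoxy to methoxy, with a hydrogen in place of methyl on the saturated chain carbon bound to the oxygen, gives an at least 3.3-fold lower number from compound 1 to compound 3 (0.52 log units; beyond the scatter). Among these compounds, the earlier step changed only the group on the nitrogen, so this is the first sign that the chain on the oxygen also moves the number, with the shorter chain going with the lower number in this pair. The true size of this step stays open, because compound 1 stands at a limit of the assay rather than at a number: the limit of >= 250000 nM in this assay, at which 1 of the 3 values shown sits.

The compounds shown leave open whether the number would keep falling with a hydroxy group in this place, or turn back with a longer chain such as propoxy. Also open, on these data alone, is whether methoxy would act the same way in compound 2, which keeps ethoxy and carries the (1-bromoethenyl)carbonyl.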